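Chain length on the ring nitrogen and rat prostate inhibition

The source may report more compounds than this note shows. Statements on the series, on what has been measured and on what is new or still open speak of the compounds shown alone.

Measured compounds:
compound 1, `CCCn1ccc2cc(/C(C)=C/C(=O)Nc3ccccc3OCCCC(=O)O)ccc21` — 190 nM
compound 2, `CCCCn1ccc2cc(/C(C)=C/C(=O)Nc3ccccc3OCCCC(=O)O)ccc21` — 43 nM
compound 3, `CCCCCCn1ccc2cc(/C(C)=C/C(=O)Nc3ccccc3OCCCC(=O)O)ccc21` — 77 nM

Three compounds sharing one core were tested in an assay on Prostate gland for inhibition of steroid 5-alpha-reductase (Rattus norvegicus); on this read-out higher numbers stand for weaker inhibition and lower numbers for stronger inhibition. In this assay compound 1 gives 190 nM, compound 2 gives 43 nM and compound 3 gives 77 nM. The change methyl in place of hydrogen on a saturated chain carbon, three bonds along the chain from an aromatic nitrogen gave a 4.4-fold lower number from compound 1 to compound 2 (0.65 log units; beyond the scatter). The larger change propyl in place of hydrogen on a saturated chain carbon, three bonds along the chain from an aromatic nitrogen gave a 2.5-fold lower number from compound 1 to compound 3 (0.39 log units; beyond the scatter), while between compounds 2 and 3 the step was a 1.8-fold higher number from compound 2 to compound 3 (0.25 log units; within the scatter).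

Compound 4, `CCCCCCCn1ccc2cc(/C(C)=C/C(=O)Nc3ccccc3OCCCC(=O)O)ccc21`, has not been measured. It differs from compound 3 by methyl in place of hydrogen on a saturated chain carbon, six bonds along the chain from an aromatic nitrogen. The core of compound 3 differs from the core of compound 1 by propyl in place of hydrogen on a saturated chain carbon, three bonds along the chain from an aromatic nitrogen, so the change from compound 3 to compound 4 is the same kind of change as that from compound 1 to compound 2, but not the same: one sits three bonds along the chain from the aromatic nitrogen, the other six bonds along it.

The step expected for compound 4 in this assay is a 1.2-fold higher number from compound 3 to compound 4 (0.09 log units; within the scatter), smaller than the earlier one, because the extension from compound 2 to compound 3 gave only a 1.8-fold higher number from compound 2 to compound 3 (0.25 log units; within the scatter), a step within the scatter, so a further single carbon at the chain end is expected to change little. Compound 4 is accordingly estimated at 95 nM, with a likely range from 40 nM to 220 nM.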

Compound 4, half-maximal inhibitory concentration: 120 nM
The estimate for compound 4 lay 1.3-fold (0.10 log units) below the measured number; low and high end bracket the measured number.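

In this assay, methyl in place of hydrogen six bonds along the chain from an aromatic nitrogen gave a 1.6-fold higher number from compound 3 to compound 4 (0.19 log units; within the scatter), which did not repeat the clear drop seen for methyl three bonds along the chain: the same change on two cores in this assay, a 4.4-fold lower number (0.65 log units; beyond the scatter) from compound 1 to compound 2 and a 1.6-fold higher number (0.19 log units; within the scatter) from compound 3 to compound 4, 6.9-fold (0.84 log units) apart, beyond the scatter of two such steps

Propyl in place of hydrogen four bonds along the chain from an aromatic nitrogen gave a 2.8-fold higher number from compound 2 to compound 4 (0.45 log units; beyond the scatter), opposite in direction to the step for propyl three bonds along: the same change on two cores in this assay, a 2.5-fold lower number (0.39 log units; beyond the scatter) from compound 1 to compound 3 and a 2.8-fold higher number (0.45 log units; beyond the scatter) from compound 2 to compound 4, 6.9-fold (0.84 log units) apart, beyond the scatter of two such steps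

Butyl in place of hydrogen three bonds along the chain from an aromatic nitrogen gave a 1.6-fold lower number from compound 1 to compound 4 (0.20 log units; within the scatter), so in these four compounds extending the chain does not carry from one core to another as a fixed step, although the steps do not show why it fails to carry or whether the same holds for any other kind of change.

The compounds shown leave open how a longer chain, a branched chain, or a chain ending in a hydroxyl group or an amine would read on the aromatic nitrogen. They also leave open whether these chain steps would hold if the carboxylic acid of the shared core were replaced by an amide.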